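Fluorine on the benzyl arm: a cytotoxicity estimate

A few compounds are considered here, and "the series" means these few. Any claim that something is new, unique, unknown or untested is made for them only; others in the source may bear on it.

Measured compounds:
compound 1 `O=[N+]([O-])c1cc(Sc2nnnn2Cc2ccccc2)cc([N+](=O)[O-])c1` gives 127000 nM in an ADME assay on CHO-K1 cells (Cricetulus griseus) for cytotoxicity, read by MTT assay, with a stated time of 24 h; a lower number here means a stronger inhibitor, a higher number a weaker inhibitor.
compound 2 `O=[N+]([O-])c1cc(-c2nnn(Cc3ccccc3)n2)cc([N+](=O)[O-])c1` gives 150000 nM in this assay.
compound 3 `O=[N+]([O-])c1cc(-c2nnn(Cc3ccc(Br)cc3)n2)cc([N+](=O)[O-])c1` gives 55000 nM in this assay.

Compound 2 has the highest number of the three; compound 1 lies within the scatter of it, while compound 3 lies beyond it. Going by the values given here, the one single-point step among the measured compounds is a 2.7-fold lower number from compound 2 to compound 3 (0.44 log units; beyond the scatter).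

Compound 4 `O=[N+]([O-])c1cc(-c2nnn(Cc3cccc(F)c3)n2)cc([N+](=O)[O-])c1` differs from compound 2 by fluoro in place of hydrogen on an aromatic carbon. Among the compounds with values here, the only step that bears on it is the bromo step from compound 2 to compound 3, which was modest. A fluoro is a smaller entering group than bromo and sits at a different place on the same ring, so a smaller step is expected. The number for compound 4 is expected to be 110000 nM, in the range 55000 nM to 220000 nM. This estimate means a step of a 1.4-fold lower number from compound 2 to compound 4 (0.13 log units; within the scatter), expected to lie within or only just beyond the scatter.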

Compound 4, half-maximal inhibitory concentration: 315000 nM
Compound 4: the middle estimate sits 2.9-fold (0.46 log units) below what was measured, and the stated range ends below it.
By their numbers in this assay, from the lowest: compound 3; then compounds 1 and 2 (each within the scatter of the next); then compound 4.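

In this assay, going by these compounds alone, a halogen on the benzyl arm does not push the number one way only: fluoro in place of hydrogen gives a 2.1-fold higher number from compound 2 to compound 4 (0.32 log units; beyond the scatter) and so runs opposite to the bromo step, which is a 2.7-fold lower number from compound 2 to compound 3 (0.44 log units; beyond the scatter) and which had been the only such change available. The two halogen compounds therefore fall on either side of compound 2, and the exchange of 4-bromophenyl for 3-fluorophenyl spans a 5.7-fold higher number from compound 3 to compound 4 (0.76 log units; beyond the scatter) on this one arm. The numbers show that this arm can move the reading in both directions, yet nothing available accounts for the direction of either step.

The compounds shown leave open whether the opposite directions follow the halogen itself or its place on the ring, as fluoro and bromo never share a place here. On these data alone, how an amine or a carboxylic acid on the same ring would read also remains open.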